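The compounds below may be only part of what the source reports. "The series", "measured", "known", "first", "only" and "open" are said of these compounds alone.

Of the compounds shown here, three built on one shared core have been tested in a functional assay on MCF7 cells (Homo sapiens) for inhibition, read by MTT assay, with a stated time of 72 h, tested at 10 uM; on this read-out higher numbers stand for more inhibition at the one concentration tested (going by the name of the read-out) and lower numbers for less inhibition. Compound 2, `CCOC(=O)C1=C(Nc2ccccc2Br)S/C(=C\c2ccc[nH]2)C1=O`, gives 29.4% and stands highest of the two numbers reported. Compound 3, `CCOC(=O)C1=C(Nc2cccc(C(F)(F)F)c2)S/C(=C\c2ccc[nH]2)C1=O`, gives 22.9%, a gap to compound 2 that lies within the scatter. Compound 1, `CCOC(=O)C1=C(Nc2ccc(Br)cc2)S/C(=C\c2ccc[nH]2)C1=O`, gives only a limit of the assay, < 10%. Going by the values given here, the single measured step that changes one place, a number at least 19.4 percentage points higher from compound 1 to compound 2 (beyond the scatter), rests on that limit, (the limit of < 10% in this assay, at which 1 of the 3 values shown sits), so its true size is known only as a lower bound.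

The compound not yet measured is compound 4, `CCOC(=O)C1=C(Nc2ccc(C)cc2)S/C(=C\c2ccc[nH]2)C1=O`. Its change from compound 2 is 4-methylphenyl in place of 2-bromophenyl on an amine nitrogen. Among the compounds with values here, no measured pair connects these two groups directly. The step from compound 1 to compound 2 bears on it in reverse, since compound 4 carries its substituent on the phenyl as compound 1 does, though as a methyl rather than a bromine. A drop in this assay is therefore expected, of roughly that size but in the opposite direction, with a fair chance of landing at the limit again. Compound 4 is expected to give about 12%, in a range from 3% to 28%. The expected change is a number 17.4 percentage points lower from compound 2 to compound 4 (beyond the scatter).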

Compound 4, a percentage reported as inhibition, at one concentration (the size of the read-out at that concentration, not a potency): < 10%
Compound 4 ended at the assay's limit; the forecaster's own chance of this, stated with the estimate: 40%; middle value at least 2 percentage points from the limit.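

In this assay, 4-methylphenyl in place of 2-bromophenyl on the amine nitrogen gives a number at least 19.4 percentage points lower from compound 2 to compound 4 (beyond the scatter), and this size is only a lower bound. With compound 1 and compound 4 both reported at a limit rather than a number, the low reading of compound 1 is no longer seen with a 4-bromophenyl group alone, since a 4-methylphenyl group carrying no bromine gives it too. The step from bromo to methyl between these two compounds cannot be read, and neither can be ranked above the other: the limit of < 10% in this assay, at which 2 of the 4 values shown sit.

From the compounds shown here alone, how far either compound lies under that limit remains unknown. Also open, going by these compounds, is whether a chlorine or a methoxy group in place of the bromine of compound 2 would keep its reading.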